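The source may hold more compounds than are shown below. What is called first, only, known or untested is meant among the compounds shown, and "the series" means these compounds.

Compound 1 `CN1CCCN(CCn2ccc3c(Br)cccc32)CC1`: 33%
Compound 2 `C=Cc1ccc2ccn(CCN3CCCN(C)CC3)c2c1`: 79%

In an assay on HEK293 cells for binding affinity to 5-hydroxytryptamine receptor 7 (Homo sapiens), read by radioligand binding, tested at 1 uM (a higher number here means more inhibition at the concentration tested (going by the name of the read-out), a lower number less inhibition), compound 2 gives 79%, the higher of the two numbers, and compound 1 with 33% lies beyond the scatter below it. Compound 3 `CN1CCCN(CCn2ccc3ccc(-c4ccsc4)cc32)CC1` has not yet been measured in this assay. It differs from compound 2 by thiophen-3-yl in place of vinyl on an aromatic carbon. Among the compounds with values here, no measured pair shows this change, so nothing known here fixes its size. A modest downward step or none beyond the scatter is expected for compound 3, namely a number 11 percentage points lower from compound 2 to compound 3 (beyond the scatter). Compound 3 is therefore estimated at 68%, with a range from 40% to 90%.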

Compound 3, a percentage reported as inhibition, at one concentration (the size of the read-out at that concentration, not a potency): 68%
Compound 3: middle estimate and measured number agree at the digits printed; the measured number falls inside the stated range.
By their numbers in this assay, from the lowest: compound 1; then compound 3; then compound 2.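

On the aromatic carbon of the shared core, replacing vinyl (2 heavy atoms) with thiophen-3-yl (5 heavy atoms, one five-membered aromatic ring) gives a number 11 percentage points lower from compound 2 to compound 3 (beyond the scatter) in this assay, a modest loss. This position therefore accepts an aromatic ring, and compound 3 still reaches 68%. Nothing measured here explains the step.

A single pair cannot show whether the loss follows from the ring, its sulfur or the added atoms. Going by these compounds, how an amine, a carboxylic acid or a phenyl ring at this carbon would compare also remains open.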